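A few compounds are considered here, and "the series" means these few. Any claim that something is new, unique, unknown or untested is made for them only; others in the source may bear on it.

Measured compounds in an assay on HEK293 cells for inhibition of cyclin-dependent kinase 14 (Homo sapiens), with a stated time of 4 h; on this read-out lower numbers stand for stronger inhibition and higher numbers for weaker inhibition:
Compound 1, `CCC(=O)Nc1cccc(S(=O)(=O)N2CCC(NC(=O)c3n[nH]cc3NC(=O)c3c(Cl)cccc3Cl)CC2)c1`, gives > 1000 nM, which is a limit of the assay and not a number.
Compound 2, `CN(C)C/C=C/C(=O)Nc1cccc(S(=O)(=O)N2CCC(NC(=O)c3n[nH]cc3NC(=O)c3c(Cl)cccc3Cl)CC2)c1`, gives 50 nM.

Going by the values given here, compound 2 thus stands as the only real number among the two values shown; the other value is the limit at which compound 1 sits (the limit of > 1000 nM in this assay, at which 1 of the 2 values shown sits). Among the compounds with values here, the single measured step, an at least 20-fold lower number from compound 1 to compound 2 (1.30 log units; beyond the scatter), changes the group on the carbonyl carbon of the anilide and leaves the benzamide ring untouched.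

Compound 3, `COc1cccc(Cl)c1C(=O)Nc1c[nH]nc1C(=O)NC1CCN(S(=O)(=O)c2cccc(NC(=O)/C=C/CN(C)C)c2)CC1`, differs from compound 2 by methoxy in place of chloro on an aromatic carbon, so that 2,6-dichlorophenyl becomes 2-chloro-6-methoxyphenyl. Within the data shown here, no measured step touches this ring, so the data give no guide to the size or direction of the change; a step within the scatter is the plainest expectation, a 1.6-fold higher number from compound 2 to compound 3 (0.20 log units; within the scatter). Compound 3 is therefore estimated to give about 80 nM in this assay. Its expected range runs from 25 nM to 300 nM.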

Compound 3, half-maximal inhibitory concentration: 50 nM
The estimate for compound 3 lay 1.6-fold (0.20 log units) above the measured number; low and high end bracket the measured number.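

Methoxy in place of chloro on this aromatic carbon gives, in this assay, no change at the digits printed from compound 2 to compound 3 (within the scatter). The earlier compounds shown here carried the 2,6-dichlorophenyl group throughout, whereas this result shows that one chloro of that ring can be exchanged for methoxy, which brings one more heavy atom and a hydrogen-bond acceptor, with the read-out staying within the scatter. Nothing measured here explains why the number holds at this place.

The compounds shown leave open whether ethoxy, fluoro or an amine at this place would also leave the number within the scatter. They also leave open whether the second chloro can be exchanged as well, as in a 2,6-dimethoxyphenyl group.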